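Swapping the sulfur-linked ring on the amide side chain

A few compounds are considered here, and "the series" means these few. Any claim that something is new, unique, unknown or untested is made for them only; others in the source may bear on it.

Three compounds share one core, an amide-bearing phenyl carrying a methylated five-ring with two further phenyl rings. Compound 1 `Cn1c(-c2ccc(NC(=O)CCl)cc2)nc(-c2ccccc2)c1-c1ccccc1` ends its amide side chain in a chlorine; compound 2 `Cn1nnnc1SCC(=O)Nc1ccc(-c2nc(-c3ccccc3)c(-c3ccccc3)n2C)cc1` carries a (1-methyl-1H-tetrazol-5-yl)sulfanyl group there instead. In a functional assay on MCF7 cells (Homo sapiens) for cytotoxicity, read by MTT assay, with a stated time of 24 h, tested at 1.6 ug/mL (a lower number here means a weaker effect, a higher number a stronger effect of the compound at the concentration tested), compound 1 gives 4.3%, and compound 2 gives 34.3%, a change described as a number 30 percentage points higher from compound 1 to compound 2 (beyond the scatter). Among the measured compounds shown here, of the two measured compounds, compound 2 stands highest, with compound 1 as its only neighbour.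

Compound 3 `Cn1c(-c2ccc(NC(=O)CSC3=NCCS3)cc2)nc(-c2ccccc2)c1-c1ccccc1` keeps the sulfur on the saturated chain carbon but changes the ring attached to it: a group of 5 heavy atoms (3 carbon, 1 nitrogen, 1 sulfur; one five-membered non-aromatic ring with 2 hetero atoms) in place of a group of 6 heavy atoms (2 carbon, 4 nitrogen; one five-membered aromatic ring with 4 hetero atoms), on a sulfur. For the measured compounds named here, no measured step covers this exact change; the single step from compound 1 to compound 2 concerns the sulfur-linked ring entering in place of chlorine, not one sulfur-linked ring in place of another. That step shows the sulfur-linked arrangement can matter, but gives no direction for a smaller, non-aromatic ring.

Compound 3 is therefore expected to land near compound 2 with a wide range, estimated at 27%, between 8% and 46%. The expected step is a number 7.3 percentage points lower from compound 2 to compound 3 (within the scatter), not clearly beyond the scatter.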

Compound 3, a percentage reported as activity, at one concentration (the size of the read-out at that concentration, not a potency): 16.2%
The estimate for compound 3 lay 10.8 percentage points above the measured number, and the stated range covers the measured number.
By their numbers in this assay, from the lowest: compound 1; then compound 3; then compound 2.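

The ring on the sulfur is not interchangeable at this position: in this assay, replacing the 1-methyl-1H-tetrazol-5-yl group with the non-aromatic ring gives a number 18.1 percentage points lower from compound 2 to compound 3 (beyond the scatter). Among the compounds shown here, the earlier step showed only that one sulfur-linked ring could outperform chlorine, whereas this result shows that the identity of that ring also changes the read-out. The second ring still keeps an advantage over chlorine, with a number 11.9 percentage points higher from compound 1 to compound 3 (beyond the scatter), so both sulfur-linked compounds stand above compound 1, although by different amounts. No outside measurement here explains why the two rings differ.

This single swap changes ring aromaticity, the number of heavy atoms and the kinds of hetero atoms together, so the compounds shown cannot reveal which of these differences goes with the lower number for compound 3. Still open, from the compounds shown here alone, are how a 1-phenyl-1H-tetrazol-5-yl group on the sulfur would compare, and what an amine such as morpholine would give on the saturated chain carbon in place of the whole sulfur-linked group.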